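Replacing the sulfonamide arm of a weak MCF7 inhibitor

The compounds below may be only part of what the source reports. "The series", "measured", "known", "first", "only" and "open" are said of these compounds alone.

Three compounds share a core in which a benzyl-protected lactone carries a triazole through a short linker. Compound 1 `CCCCCc1ccc(-c2cn(C/C=C3\OC(=O)C(OCc4ccccc4)=C3OCc3ccccc3)nn2)cc1` reaches only the limit > 100000 nM in a functional assay on MCF7 cells (Homo sapiens) for antiproliferative activity, read by MTT assay, with a stated time of 72 h (a lower number here means a stronger inhibitor, a higher number a weaker inhibitor), which is a limit of the assay and not a number. Compound 2 `O=C1O/C(=C\Cn2cc(-c3cc(C(F)(F)F)cc(C(F)(F)F)c3)nn2)C(OCc2ccccc2)=C1OCc1ccccc1` likewise gives only the limit > 100000 nM in this assay. Going by the values given here, compound 3 `O=C1O[C@H]([C@@H](O)Cn2cc(CNS(=O)(=O)c3ccc(F)cc3)nn2)C(OCc2ccccc2)=C1OCc1ccccc1`, with a saturated hydroxyl-bearing linker, is the one compound with a measured number in this assay, 26800 nM; it thus stands alone, since the other two values sit at the limit of > 100000 nM in this assay, at which 2 of the 3 values shown sit.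

Compound 4 `Cc1ccc(-c2cn(C[C@H](O)[C@H]3OC(=O)C(OCc4ccccc4)=C3OCc3ccccc3)nn2)cc1` keeps the linker of compound 3 but differs in the group on the triazole: 4-methylphenyl in place of (((4-fluorophenyl)sulfonyl)amino)methyl on an aromatic carbon. Among the compounds with values here, with no measured step to compare, the author expects a moderate loss of potency beyond the scatter, with a fair chance that only a limit is reported. For compound 4 the expected step is a 2.2-fold higher number from compound 3 to compound 4 (0.35 log units; beyond the scatter), so that compound 4 is estimated at 60000 nM in this assay, between 20000 nM and 200000 nM.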

Compound 4, half-maximal inhibitory concentration: > 100000 nM
Compound 4 ended at the assay's limit (the forecaster's own chance of this, stated with the estimate: 40%); middle value at least 1.6-fold (0.22 log units) away from the limit.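

On the aromatic carbon of the triazole, with the saturated hydroxyl-bearing linker kept, the change to 4-methylphenyl from (((4-fluorophenyl)sulfonyl)amino)methyl gives an at least 3.7-fold higher number from compound 3 to compound 4 (0.57 log units; beyond the scatter) in this assay. The value of compound 4 is a limit of the assay and not a number, so this step is a lower bound, and it shows that the linker of compound 3 does not by itself secure a measured value once the sulfonyl-bearing arm is gone. Compound 3 remains the only compound with a number, and the others share one limit: the limit of > 100000 nM in this assay, at which 3 of the 4 values shown sit.

From the compounds shown here alone, it remains open whether the sulfonylamino link or the 4-fluorophenyl ring accounts for the difference. Nor do these compounds show whether a plain aminomethyl group, a carboxylic acid or a carboxamide at this place would keep a measurable value.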